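The compounds below may be only part of what the source reports. "The series", "measured", "known", "first", "only" and "open" are said of these compounds alone.

Compound 1, `CC(C)C(=O)N1CC2CC(C1)N2`: 20000 nM
Compound 2, `O=C(C1CCC1)N1CC2CC(C1)N2`: 11000 nM

Both numbers come from an assay on SH-EP1 cells for agonist activity at Neuronal acetylcholine receptor; alpha4/beta2 (Homo sapiens), read by FLIPR and calcium flux; on this read-out higher numbers stand for an effect only at larger amounts of compound and lower numbers for an effect already at smaller amounts. Within the data shown here, compound 2 holds the lower of the two, and its nearest neighbour is compound 1; the single measured step, a 1.8-fold lower number from compound 1 to compound 2 (0.26 log units; within the scatter), came with cyclobutyl in place of isopropyl on a carbonyl carbon and stayed within the scatter, so the two compounds cannot be ranked against each other.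

Compound 3, `O=C([C@@H]1C[C@@H]1F)N1CC2CC(C1)N2`, is the next compound built on the same shared core. It differs from compound 2 in one place: 2-fluorocyclopropyl in place of cyclobutyl on a carbonyl carbon. Among the measured compounds shown here, the only step that bears on this change is a 1.8-fold lower number from compound 1 to compound 2 (0.26 log units; within the scatter), in which one group on the carbonyl carbon gave way to another without a shift beyond the scatter. For the measured compounds named here, no measured compound carries fluorine, so nothing in the data speaks to that part of the change. The expectation is therefore for compound 3 to stay close to compound 2 in this assay, which is a 1.1-fold lower number from compound 2 to compound 3 (0.04 log units; within the scatter). Compound 3 is estimated at 10000 nM, with a range from 3000 nM to 30000 nM.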

Compound 3, half-maximal effective concentration: 370 nM
Estimate against measurement, compound 3: 27-fold (1.43 log units) above; the measured number lies below the stated range.
By their numbers in this assay, from the lowest: compound 3; then compounds 2 and 1 (each within the scatter of the next).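

At this position the group on the carbonyl carbon can matter a great deal in this assay, which the earlier pair of isopropyl and cyclobutyl gave no sign of. Putting 2-fluorocyclopropyl in place of cyclobutyl gives a 30-fold lower number from compound 2 to compound 3 (1.47 log units; beyond the scatter) and putting it in place of isopropyl gives a 54-fold lower number from compound 1 to compound 3 (1.73 log units; beyond the scatter) so both steps lie well beyond the scatter, even though the entering group has the same count of heavy atoms as the cyclobutyl it replaces. No measurement shown here accounts for the size of these steps, and the reason for them remains unknown.

The compounds shown leave open whether the fluorine, the three-membered ring or the two together lie behind the lower number, as a plain cyclopropyl group on the same carbonyl carbon is not among them. They also leave open whether the defined arrangement at the two stereocentres matters, a question that the other arrangements of 2-fluorocyclopropyl could answer, and how a 2,2-difluorocyclopropyl group would compare.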